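A few compounds are considered here, and "the series" means these few. Any claim that something is new, unique, unknown or untested is made for them only; others in the source may bear on it.

Measured so far in an ADME assay on microsomes from liver (Homo sapiens) for metabolic stability, read by mass spectrometry, with a stated time of 10 min, tested at 0.5 uM; a higher number here means that more of the compound is left, a lower number that less of the compound is left
- compound 1 `CNc1cc(Nc2cc(C)cc(C)c2)nn2c(C(N)=O)cnc12` gives 15%
- compound 2 `CNc1cc(Nc2c(F)c(F)cc(F)c2F)nn2c(C(=O)NC[C@](C)(O)CO)cnc12` gives 100%

Compound 1 holds the lower of the two numbers, and the gap to compound 2 lies beyond the scatter. Compound 3 `CNc1cc(Nc2cc(C)cc(C)c2)nn2c(C(=O)NC3CC3)cnc12` differs from compound 1 by cyclopropyl in place of hydrogen on an amide-type nitrogen. Compound 2 differs from compound 1 in more than one place, so no measured single change guides this one. The expected result is a number 7 percentage points higher from compound 1 to compound 3 (within the scatter), a small upward step that probably stays within the scatter. In this assay the estimate for compound 3 is 22%, with an expected range of 8% to 50%.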

Compound 3, percent of the compound remaining: 11%
The estimate for compound 3 lay 11 percentage points above the measured number, within the range that was stated.
By their numbers in this assay, from the lowest: compounds 3 and 1 (each within the scatter of the next); then compound 2.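

In this assay cyclopropyl in place of hydrogen on an amide-type nitrogen gives a number 4 percentage points lower from compound 1 to compound 3 (within the scatter) as the first single change read at this position. Adding this small ring to the amide nitrogen therefore leaves the two compounds indistinguishable in this read-out. No measured evidence bears on this result. 

Going by these compounds, whether a longer alkyl chain or a carboxylic acid on that nitrogen would give a step beyond the scatter remains open. Also open, on these data alone, is how much the amide substituent of compound 2 contributes to its number, since that compound differs from compound 1 in more than one place.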